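The compounds below may be only part of what the source reports. "The series", "measured", "known", "first", "only" and "open" are said of these compounds alone.

- Compound 1 `COc1cc(/C=C/C(=O)/C=C/c2cccs2)ccc1OCc1cn(CCOc2cc(=O)oc3ccccc23)nn1`: 7140 nM
- Compound 2 `COc1cccc(/C=C/C(=O)/C=C/c2ccc(OCc3cn(CCOc4cc(=O)oc5ccccc45)nn3)c(OC)c2)c1`: 7130 nM
- Compound 3 `COc1ccc(/C=C/C(=O)/C=C/c2ccc(OCc3cn(CCCOc4cc(=O)oc5ccccc45)nn3)c(OC)c2)cc1OC`: 8510 nM

In a functional assay on THP-1 cells (Homo sapiens) for cytotoxicity, read by sulforhodamine B assay, with a stated time of 48 h (a lower number here means a stronger inhibitor, a higher number a weaker inhibitor), compound 1 gives 7140 nM, and its number lies within the scatter of the numbers of compound 2 and compound 3. Compound 4 `COc1cc(/C=C/C(=O)/C=C/c2ccco2)ccc1OCc1cn(CCOc2cc(=O)oc3ccccc23)nn1` keeps the rest of compound 1 and changes one group on a double-bonded chain carbon bound to a double-bonded chain carbon: furan-2-yl in place of thiophen-2-yl on a double-bonded chain carbon bound to a double-bonded chain carbon. For the measured compounds named here, only one measured step touches this same place, replacing thiophen-2-yl with 3-methoxyphenyl. That step is a 1.0-fold lower number from compound 1 to compound 2 (0.00 log units; within the scatter), so even this larger replacement left no change beyond the scatter. Going by the values given here, no measured compound yet carries furan-2-yl, so the expectation rests on that single step. The estimated step is a 1.0-fold higher number from compound 1 to compound 4 (0.00 log units; within the scatter), which is not expected to exceed the scatter. For compound 4 the estimated value is 7200 nM, with an expected range of 4000 nM to 13000 nM.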

Compound 4, half-maximal inhibitory concentration: 7870 nM
Estimate against measurement, compound 4: 1.1-fold (0.04 log units) below; measured number inside the range.
By their numbers in this assay, from the lowest: compounds 2, 1, 4 and 3 (each within the scatter of the next).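

In this assay, exchanging the ring sulfur of thiophen-2-yl for the oxygen of furan-2-yl gives a 1.1-fold higher number from compound 1 to compound 4 (0.04 log units; within the scatter) and replacing 3-methoxyphenyl with furan-2-yl gives a 1.1-fold higher number from compound 2 to compound 4 (0.04 log units; within the scatter) as well. This place on the chain has now carried three different aromatic groups, two of them five-membered rings, with no step beyond the scatter. As far as these compounds go, whether a group of another kind here, such as an amine or a carboxylic acid, would move the number stays open. Nothing measured on these compounds explains why these groups read alike.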